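A few compounds are considered here, and "the series" means these few. Any claim that something is new, unique, unknown or untested is made for them only; others in the source may bear on it.

Measured so far:
compound 1 `CN(C)c1ccc(C(=O)N2CCCCc3ccccc32)c(Cl)c1` — 18 nM
compound 2 `CCNc1ccc(C(=O)N2CCCCc3cc(Cl)ccc32)c(Cl)c1` — 5 nM
compound 3 `CCCNc1ccc(C(=O)N2CCCCc3ccccc32)c(Cl)c1` — 18 nM

All three were tested in an assay on HeLa cells for binding affinity to Vasopressin V2 receptor (Homo sapiens); a lower number here means a stronger inhibitor, a higher number a weaker inhibitor. Compound 1 gives 18 nM there, and compound 3 gives 18 nM, so the two stand level at the digits shown and together hold the highest numbers of the three. Compound 2, with 5 nM, sits clearly lower than compound 1, and that gap lies beyond the scatter.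

Compound 4 `Cc1ccn(-c2ccc(C(=O)N3CCCCc4ccccc43)c(Cl)c2)n1` differs from compound 1 in one place: 3-methyl-1H-pyrazol-1-yl in place of dimethylamino on an aromatic carbon. Among the measured compounds shown here, the only measured step that touches this position is no change at the digits printed from compound 1 to compound 3 (within the scatter), where propylamino replaced dimethylamino on the same carbon and the number did not move. That step shows the position tolerates a change of substituent, but it does not involve a ring entering, so it bears on compound 4 only loosely. The expectation is therefore for no shift beyond the scatter in this assay, with wide uncertainty. Compound 4 is estimated at 20 nM, within 6 nM to 70 nM, which means an expected step of a 1.1-fold higher number from compound 1 to compound 4 (0.05 log units; within the scatter).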

Compound 4, half-maximal inhibitory concentration: 13 nM
Estimate against measurement, compound 4: 1.5-fold (0.19 log units) above, within the range that was stated.
By their numbers in this assay, from the lowest: compound 2; then compounds 4, 1 and 3 (each within the scatter of the next).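

The aromatic carbon para to a large group accepts more than open-chain amino groups: a five-membered aromatic ring with 2 hetero atoms can stand there, and neither step moves the number beyond the scatter in this assay (a 1.4-fold lower number from compound 1 to compound 4 (0.14 log units; within the scatter); a 1.4-fold lower number from compound 3 to compound 4 (0.14 log units; within the scatter)). Within this small set, then, dimethylamino, propylamino and 3-methyl-1H-pyrazol-1-yl are interchangeable at this carbon, even though the new group has more heavy atoms and no nitrogen-carbon chain of the earlier kind. No measurement here explains this tolerance.

Still open, on these data alone, is how the number would respond to plain 1H-pyrazol-1-yl, without the methyl, or to a morpholine or a carboxylic acid on this carbon. A phenyl group there would show whether the ring's nitrogen atoms count for anything.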